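The source may report more compounds than this note shows. Statements on the series, on what has been measured and on what is new or still open speak of the compounds shown alone.

Of the compounds shown here, three built on one shared core have been measured in a functional assay on CHO cells with adenosine receptor A1 (Homo sapiens) as the target, read by cAMP accumulation and immunoassay, with a stated time of 6 min, tested at 0.1 uM; on this read-out lower numbers stand for a stronger effect and higher numbers for a weaker effect at the one concentration tested. Compound 1 `CC(C)N1CCN(Cc2csc(N)c2C(=O)c2ccc(Cl)cc2)CC1` gives 3.6%. Compound 2 `Nc1scc(CN2CCN(c3ccc(Cl)cc3F)CC2)c1C(=O)c1ccc(Cl)cc1` gives -9.4%. Compound 3 `Nc1scc(CN2CCN(c3ccccc3F)CC2)c1C(=O)c1ccc(Cl)cc1` gives -1%, the second highest of the three numbers; its nearest neighbour is compound 1 and its furthest is compound 2, and both of those gaps lie within the scatter. Compound 4 `Nc1scc(CN2CCN(c3ccc(F)c(F)c3)CC2)c1C(=O)c1ccc(Cl)cc1` awaits measurement. It differs from compound 3 at the same place where the three measured compounds differ from one another: 3,4-difluorophenyl in place of 2-fluorophenyl on an amine nitrogen in a ring.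

Two kinds of measured step bear on this change. Replacing isopropyl on the ring nitrogen by an aryl group gave a number 4.6 percentage points lower from compound 1 to compound 3 (within the scatter) and a number 13 percentage points lower from compound 1 to compound 2 (beyond the scatter), and hydrogen in place of chloro on the aromatic carbon gave a number 8.4 percentage points higher from compound 2 to compound 3 (within the scatter). For the measured compounds named here, only the step from compound 1 to compound 2 exceeds the scatter, and it points downward; the other two changes on the aryl group stayed within it. Compound 4 keeps a fluorine-bearing aryl group on that nitrogen, so a step of a number 3 percentage points lower from compound 3 to compound 4 (within the scatter) is expected, not beyond the scatter. Compound 4 is therefore estimated at -4%, with a range from -15% to 7%.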

Compound 4, a percentage reported as activity, at one concentration (the size of the read-out at that concentration, not a potency): -34%
Compound 4: the middle estimate sits 30 percentage points above what was measured; measured number below the stated range.
By their numbers in this assay, from the lowest: compound 4; then compounds 2, 3 and 1 (each within the scatter of the next, the first and the last beyond it).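

In this assay, for the compounds shown here, the aryl group on the amine nitrogen in the ring proves to matter much more than the earlier compounds showed: 3,4-difluorophenyl in place of 2-fluorophenyl gave a number 33 percentage points lower from compound 3 to compound 4 (beyond the scatter), whereas the earlier change between two aryl groups stayed within the scatter. The same group also separates clearly from the other two substituents, with a number 24.6 percentage points lower from compound 2 to compound 4 (beyond the scatter) and a number 37.6 percentage points lower from compound 1 to compound 4 (beyond the scatter), so compound 4 shows the strongest effect of the four at the one concentration tested. The data shown offer no explanation for a step of this size.

The step from 2-fluorophenyl to 3,4-difluorophenyl changes the fluorine pattern as a whole, so the compounds shown do not reveal whether the shift depends on having both fluorines of the new group or on losing the fluorine of the old one. A 3-fluorophenyl or a 4-fluorophenyl group would help to separate these readings, and a 3,4-dichlorophenyl group would test whether fluorine itself is needed, while the single concentration leaves the potency of compound 4 open.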